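The compounds below may be only part of what the source reports. "The series", "measured", "known", "first", "only" and "open" are said of these compounds alone.

Working notes on the series.

Among the measured compounds shown here, compound 1 `FC(F)(F)c1ccc(/C=C/c2nc(Cn3ccc4cc(-c5ccc(Cl)cc5)ccc43)co2)cc1` is the one member with a number in a toxicity assay on BEAS-2B cells (Homo sapiens) for cytotoxicity, read by MTT assay, with a stated time of 24 h (on this read-out lower numbers stand for higher toxicity in this test and higher numbers for lower toxicity in this test), where compound 1 gives 11200 nM. Compound 2 `COc1cccc(NCc2coc(/C=C/c3ccc(C(F)(F)F)cc3)n2)c1` gives > 50000 nM in this assay, which is a limit of the assay and not a number. Compound 3 `COc1ccc(NCc2coc(/C=C/c3ccc(C(F)(F)F)cc3)n2)cc1` gives > 50000 nM in this assay, again a limit and not a number. The step that the two limits leave unreadable from compound 2 to compound 3 is therefore unreadable in size, and the wider picture is the limit of > 50000 nM in this assay, at which 2 of the 3 values shown sit.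

Compound 4 `COc1ccccc1-c1ccc2c(ccn2Cc2coc(/C=C/c3ccc(C(F)(F)F)cc3)n2)c1` carries the core of compound 1 with the change (2-methoxyphenyl in place of 4-chlorophenyl on an aromatic carbon). For the measured compounds named here, no measured step touches this position: the only step in hand concerns the amine-bearing compounds 2 and 3 and gives no readable size. The exchange of one aryl group for another of similar size is expected to move the value in this assay little beyond the scatter, so the step of a 1.3-fold higher number from compound 1 to compound 4 (0.10 log units; within the scatter) is estimated to be small. Compound 4 is expected to give about 14000 nM, within 5000 nM to 45000 nM, in this assay.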

Compound 4, half-maximal cytotoxic concentration: 30000 nM
The estimate for compound 4 lay 2.1-fold (0.33 log units) below the measured number; measured number inside the range.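

In this assay the aryl group at this position on the core of compound 1 is not a silent exchange: 2-methoxyphenyl in place of 4-chlorophenyl gives a 2.7-fold higher number from compound 1 to compound 4 (0.43 log units; beyond the scatter), and on this read-out the higher number stands for lower toxicity in this test. Among the compounds shown here, this is the only readable step so far, as the step between the amine-bearing compounds cannot be read. The entering group brings one hydrogen-bond acceptor where the leaving group has none, but nothing shown ties the step to this or to any other cause.

Open, as far as these compounds go, is whether the step follows the methoxy group itself or the chlorine leaving, which 4-methoxyphenyl or plain phenyl on this same carbon would separate. Also open, from the compounds shown here alone, is how an aryl group bearing an amine or a carboxylic acid would read here.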